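A Methyl Added to the Core of Compound 1

The source may report more compounds than this note shows. Statements on the series, on what has been measured and on what is new or still open speak of the compounds shown alone.

Compound 1 `COC(=O)[C@@]1(C)CCC=C2[C@@H]1CC[C@@H](C)[C@]2(C)Cc1c[nH]c2ccc(Cl)cc12`: 11000 nM
Compound 2 `COC(=O)[C@@]1(C)CCC=C2[C@@H]1CC[C@@H](C)[C@]2(C)Cc1c[nH]c2ccc(C(F)(F)F)cc12`: 14000 nM

In a functional assay on SW1573 cells (Homo sapiens) for inhibition, read by sulforhodamine B assay, with a stated time of 48 h (on this read-out lower numbers stand for stronger inhibition of growth and higher numbers for weaker inhibition of growth), compound 1 stands at the lower of the two numbers, though the step of a 1.3-fold higher number from compound 1 to compound 2 (0.10 log units; within the scatter) lies within the scatter. Compound 3 `COC(=O)[C@@]1(C)CCC=C2[C@@H]1CC[C@@H](C)[C@]2(C)Cc1c(C)[nH]c2ccc(Cl)cc12` differs from compound 1 by methyl in place of hydrogen on an aromatic carbon. Going by the values given here, the single measured step, a 1.3-fold higher number from compound 1 to compound 2 (0.10 log units; within the scatter), concerns a different position and was within the scatter, so nothing measured bears on adding a methyl here. Compound 3 is therefore expected to show no step beyond the scatter, no change at the digits printed from compound 1 to compound 3 (within the scatter), and its estimated value is 11000 nM, ranging from 4000 nM to 30000 nM.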

Compound 3, concentration for 50% growth inhibition: 14000 nM
Beside the measured number, compound 3's estimate is 1.3-fold (0.10 log units) below it, within the range that was stated.
By their numbers in this assay, from the lowest: compounds 1, 2 and 3 (each within the scatter of the next).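

Methyl in place of hydrogen on this aromatic carbon, next to the ring nitrogen and next to the ring atom that bears a large group, gives in this assay the following step: a 1.3-fold higher number from compound 1 to compound 3 (0.10 log units; within the scatter). Going by these compounds alone, this is the first measurement at this position, and this single methyl leaves the number within the scatter. Nothing available explains this result. Going by these compounds, whether a longer chain, an amine or a carboxylic acid on this carbon would move the number stays open. Also open, on these data alone, is whether the methyl would behave the same with trifluoromethyl in place of chloro.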